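A few compounds are considered here, and "the series" means these few. Any claim that something is new, unique, unknown or untested is made for them only; others in the source may bear on it.

Measured so far:
- compound 1 `COc1cc2c(cc1OC)C(CC(N)=O)CC2`: 27.8%
- compound 2 `COc1cc2c(cc1OC)C(CC(=O)NC(C)C)CC2`: 37%

In a functional assay on the whole organism (strain Wistar) for inhibition, with Rattus norvegicus as the target, read by paw edema, with stated times of 60 min and 6 h, at a dose of 100 mg/kg by the oral route (on this read-out lower numbers stand for less inhibition and higher numbers for more inhibition at the one dose given (going by the name of the read-out)), compound 2 gives 37%, and compound 1 gives 27.8%. These two numbers lie within the usual scatter of each other, so neither compound can be set above the other on this read-out. For the measured compounds named here, the only step measured so far, a number 9.2 percentage points higher from compound 1 to compound 2 (within the scatter), put isopropyl in place of hydrogen on an amide-type nitrogen and changed the read-out by less than the scatter.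

Compound 3 `CCCCNC(=O)CC1CCc2cc(OC)c(OC)cc21` has not yet been measured. It differs from compound 2 by butyl in place of isopropyl on an amide-type nitrogen. Going by the values given here, the one measured step bears on it only loosely: it concerns the same amide-type nitrogen, where a change from hydrogen to isopropyl left the read-out essentially unchanged. Among the compounds with values here, no step from isopropyl to butyl has been measured, so the expectation rests on that single neighbouring step alone. The step from compound 2 to compound 3 is therefore expected to be small, a number 3 percentage points higher from compound 2 to compound 3 (within the scatter), with no clear direction beyond the scatter. Compound 3 is thus expected to give about 40%, within a range from 25% to 55%.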

Compound 3, a percentage reported as inhibition, in the whole organism at one dose (the size of the read-out at that dose, not a potency): 24.1%
Estimate against measurement, compound 3: 15.9 percentage points above; the whole stated range lies above it.
By their numbers in this assay, from the lowest: compounds 3, 1 and 2 (each within the scatter of the next, the first and the last beyond it).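

In this assay, the nitrogen of the amide proves able to tell two small carbon groups apart: butyl in place of isopropyl on this amide-type nitrogen gives a number 12.9 percentage points lower from compound 2 to compound 3 (beyond the scatter), a modest step but one that, unlike the earlier change from hydrogen to isopropyl, goes beyond the scatter. Putting butyl in place of hydrogen on the same nitrogen gives a number 3.7 percentage points lower from compound 1 to compound 3 (within the scatter), so butyl cannot be told apart from the plain amide, and the difference shows only between the two carbon groups themselves. Nothing measured here says why isopropyl and butyl part in this way.

Three compounds cannot show whether branching or chain length is what matters, and a tert-butyl group or a longer chain such as hexyl on the same nitrogen would be needed to start separating the two. Also open, going by these compounds, is how a ring on this nitrogen, such as cyclohexyl or phenyl, or a carboxylic acid in place of the whole amide, would read in this assay.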